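The compounds below may be only part of what the source reports. "The series", "measured", "known", "first", "only" and "open" are said of these compounds alone.

Working notes on the series, characterised in an assay for binding affinity to adenosine receptor A1 (Bos taurus); on this read-out higher numbers stand for weaker inhibition and lower numbers for stronger inhibition.

Among the compounds with values here, compound 1 `CCn1c(=O)c2nc(-c3ccc(S(=O)(=O)O)cc3)[nH]c2n(CC)c1=O` gives 755 nM in this assay, the highest of the three numbers known so far. Compound 2 `CN(C)c1cccc(-c2nc3c(=O)n(C)c(=O)n(C)c3[nH]2)c1` gives 80 nM in this assay, the nearest to compound 1 and beyond the scatter from it. Compound 3 `C=CCn1c(=O)c2[nH]c(-c3ccc(Cl)cc3N)nc2n(C)c1=O` gives 2 nM in this assay, the furthest from compound 1, also beyond the scatter. No two of the measured compounds differ in one place only, so no single step is shown among them.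

Compound 4 `CCn1c(=O)c2nc(-c3ccc(S(=O)(=O)NCCCN(C)C)cc3)[nH]c2n(CC)c1=O` has not been measured. From compound 1 it differs in one place: (3-(dimethylamino)propyl)amino in place of hydroxy on a sulfonyl sulfur. The shared core and the aromatic ring are untouched, and the sulfonyl sulfur keeps its aromatic carbon neighbour.

Within the data shown here, no measured pair carries this change, so the expectation rests on compound 1 alone. The step is expected to be a 7.6-fold lower number from compound 1 to compound 4 (0.88 log units; beyond the scatter), toward a lower number and beyond the scatter. Compound 4 is estimated at 100 nM in this assay, with a range from 25 nM to 400 nM.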

Compound 4, half-maximal inhibitory concentration: 1.6 nM
Compound 4: middle estimate off by 63-fold (1.80 log units), on the high side; the measured number lies below the stated range.
By their numbers in this assay, from the lowest: compounds 4 and 3 (each within the scatter of the next); then compound 2; then compound 1.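

Read in this assay, replacing hydroxy with (3-(dimethylamino)propyl)amino on the sulfonyl sulfur gives a 470-fold lower number from compound 1 to compound 4 (2.67 log units; beyond the scatter) with the shared core and the aromatic ring untouched. Within the data shown here, this is the first single-place step, and it shows that this position accepts a group of far more heavy atoms, with the change from sulfo to (3-(dimethylamino)propyl)sulfamoyl alone moving the number well beyond the scatter. No measurement shown accounts for the size of this step.

Still open, on these data alone, is whether the step depends on the terminal dimethylamino group or on the chain and sulfonamide link, which a plain amino or methylamino group on the sulfonyl sulfur would help separate. A longer chain, or a morpholine at the chain end, would show how far this position extends.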